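The compounds below may be only part of what the source reports. "The series", "measured", "known", "first", "only" and "open" are said of these compounds alone.

Of the compounds shown here, three sharing one core have been tested in an ADME assay on SH-SY5Y cells (Homo sapiens) for cytotoxicity, read by MTT assay, with a stated time of 24 h, tested at 50 uM; a lower number here means a stronger effect, a higher number a weaker effect of the compound at the concentration tested. Compound 1 `COc1cc2c(cc1O)CCC(C)(CC(=O)O)O2` gives 61%, compound 2 `COc1cc2c(cc1O)CCC(C)(CC(N)=O)O2` gives 99.2%, and compound 3 `COc1cc2c(cc1O)CCC(C)(CCNC(C)=O)O2` gives 66.5%. Compound 3 thus stands second highest of the three, close to compound 1 and well apart from compound 2. Compound 4 `COc1cc2c(cc1O)CCC(C)(CC(N)C(=O)O)O2` has not yet been measured; it differs from compound 3 in one place: amino(carboxy)methyl in place of acetamidomethyl on a saturated chain carbon bound to a saturated ring carbon. Two measured steps at the same place bear on this: a number 5.5 percentage points higher from compound 1 to compound 3 (within the scatter), and a number 32.7 percentage points lower from compound 2 to compound 3 (beyond the scatter). A third step, a number 38.2 percentage points higher from compound 1 to compound 2 (beyond the scatter), separates the carboxy compound from the carbamoyl compound. Compound 4 carries a carboxy group, as compound 1 does with 61%, so the step expected here is a number 2.5 percentage points lower from compound 3 to compound 4 (within the scatter). Compound 4 is therefore estimated at 64%, ranging from 48% to 85%.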

Compound 4, a percentage reported as activity, at one concentration (the size of the read-out at that concentration, not a potency): 85.7%
Estimate against measurement, compound 4: 21.7 percentage points below; measured number above the stated range.
By their numbers in this assay, from the lowest: compounds 1 and 3 (each within the scatter of the next); then compound 4; then compound 2.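

In this assay the change from carboxy to amino(carboxy)methyl gives a number 24.7 percentage points higher from compound 1 to compound 4 (beyond the scatter) and so shows that a carboxy group at this place does not by itself hold the number near that of compound 1. Set against the other groups, amino(carboxy)methyl gives a number 19.2 percentage points higher from compound 3 to compound 4 (beyond the scatter) and a number 13.5 percentage points lower from compound 2 to compound 4 (beyond the scatter) and so stands clearly apart from both acetamidomethyl and carbamoyl. Nothing measured here explains these steps. Whether the new amine alone accounts for the rise stays open, and a 2-aminoethyl chain without the carboxy group would test this.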